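A few compounds are considered here, and "the series" means these few. Any claim that something is new, unique, unknown or untested is made for them only; others in the source may bear on it.

In a functional assay on NCI-H1975 cells (Homo sapiens) for inhibition, read by sulforhodamine B assay, tested at 10 uM (a lower number here means less inhibition, a higher number more inhibition at the concentration tested (going by the name of the read-out)), compound 1 `CN1CCN(c2ccc(C3=NN(C(=O)c4ccc(F)cc4)C(c4ccc(N(C)C)cc4)C3)cc2)CC1` gives 32.2%, while compound 2 `CN(C)c1ccc(C2CC(c3ccc(-n4cncn4)cc3)=NN2C(=O)c2ccc(F)cc2)cc1` gives -1.1%, the lower of the two numbers; the change between them is a number 33.3 percentage points lower from compound 1 to compound 2 (beyond the scatter). Compound 3 `CN(C)c1ccc(C2CC(c3ccc(-n4cncn4)cc3)=NN2S(=O)(=O)c2ccc(Br)cc2)cc1` differs from compound 2 at another place: (4-bromophenyl)sulfonyl in place of (4-fluorophenyl)carbonyl on an amine nitrogen in a ring. Among the measured compounds shown here, no measured pair shows this exchange, and the one known step alters a different part of the shared core, so it offers no direct guide. With nothing pointing either way, little change beyond the scatter is expected, a number 6.1 percentage points higher from compound 2 to compound 3 (within the scatter). Compound 3 is estimated at 5%, with a range from -12% to 30%.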

Compound 3, a percentage reported as inhibition, at one concentration (the size of the read-out at that concentration, not a potency): -0.6%
Compound 3: the middle estimate sits 5.6 percentage points above what was measured; the range from low to high includes it.
By their numbers in this assay, from the lowest: compounds 2 and 3 (each within the scatter of the next); then compound 1.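

In this assay, placing (4-bromophenyl)sulfonyl instead of (4-fluorophenyl)carbonyl on the ring amine nitrogen gives a number 0.5 percentage points higher from compound 2 to compound 3 (within the scatter), so this double exchange, of carbonyl for sulfonyl and fluorine for bromine, brings no inhibition at this position. Both numbers lie close to zero, so this pair cannot show whether the exchange would matter in a compound with clear inhibition. Nothing measured here offers an explanation for this result.

Still open, going by these compounds, is how the same exchange behaves with 4-methylpiperazin-1-yl in place of the 1H-1,2,4-triazol-1-yl group. Also open, on these data alone, is what a smaller group, such as methylsulfonyl or acetyl, would give on this nitrogen.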